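The source may hold more compounds than are shown below. What is called first, only, known or untested is meant among the compounds shown, and "the series" means these compounds.

Measured compounds:
Compound 1 `CC(=O)OC[C@H]1O[C@@H](n2cc(-c3cc(-c4ccc(C(C)(C)C)cc4)no3)c(=O)[nH]c2=O)C[C@@H]1OC(C)=O` gives 69.3% in a functional assay on MDA-MB-231 cells (Homo sapiens) for cytotoxicity, read by sulforhodamine B assay, tested at 10 uM; a lower number here means less inhibition, a higher number more inhibition at the concentration tested (going by the name of the read-out).
Compound 2 `CC(=O)OC[C@H]1O[C@@H](n2cc(-c3cc(-c4ccc(C(C)C)cc4)no3)c(=O)[nH]c2=O)C[C@@H]1OC(C)=O` gives 83.2% in this assay.

Compound 2 stands highest of the two numbers; its nearest neighbour is compound 1, and the step is a number 13.9 percentage points higher from compound 1 to compound 2 (beyond the scatter). Compound 3 `CC(=O)OC[C@H]1O[C@@H](n2cc(-c3cc(-c4ccccc4)no3)c(=O)[nH]c2=O)C[C@@H]1OC(C)=O` is not yet measured. It differs from compound 2 by hydrogen in place of isopropyl on an aromatic carbon, a change on the same aromatic carbon of the six-membered aromatic ring where compounds 1 and 2 differ. For the measured compounds named here, only that one step bears on it, and it shows that trimming the group on this carbon raised the inhibition by a modest amount. Trimming further, to hydrogen, has no measured precedent, so the direction is uncertain and the step is expected to be small, plausibly none beyond the scatter. Compound 3 is therefore estimated at 78%, with a range from 55% to 95%. The expected step is a number 5.2 percentage points lower from compound 2 to compound 3 (within the scatter).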

Compound 3, a percentage reported as inhibition, at one concentration (the size of the read-out at that concentration, not a potency): 95%
The estimate for compound 3 lay 17 percentage points below the measured number, and the stated range covers the measured number.
By their numbers in this assay, from the lowest: compound 1; then compound 2; then compound 3.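

In this assay, the carbon that held the alkyl group needs no substituent at all for the inhibition to rise: taking off the isopropyl group, the change from 4-isopropylphenyl to phenyl, gives a number 11.8 percentage points higher from compound 2 to compound 3 (beyond the scatter), and taking off the tert-butyl group gives a number 25.7 percentage points higher from compound 1 to compound 3 (beyond the scatter). For the compounds shown here, the earlier pair showed only a change from one alkyl group to another, whereas these three compounds now form a single order, tert-butyl, then isopropyl, then hydrogen, with inhibition rising at each step and no compound going against it. No measurement shown here explains this order.

From the compounds shown here alone, whether a methyl or an ethyl group on this carbon would fall within the same order remains open. So does the effect of a different kind of group there, such as an amine or a carboxylic acid, and of moving any group elsewhere on the six-membered ring.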